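The source may hold more compounds than are shown below. What is called first, only, known or untested is meant among the compounds shown, and "the series" means these compounds.

Compound 1 `COc1ccc(Cn2nc(-c3ccccc3)c3cc(C(=N)Nc4ccccc4)ncc32)cc1`: 5400 nM
Compound 2 `COc1ccc(Cn2ncc3cc(C(=N)Nc4ccc(N5CCN(C)CC5)cc4)ncc32)cc1`: 5700 nM

Both values come from a functional assay on MDA-MB-231 cells (Homo sapiens) for cytotoxicity, read by MTT assay, with a stated time of 72 h (on this read-out higher numbers stand for weaker inhibition and lower numbers for stronger inhibition), and lie within the usual scatter of each other, so compound 2 cannot be told apart from compound 1 on these numbers. Compound 3 `COc1ccc(Cn2ncc3cc(C(=N)Nc4ccccc4)ncc32)cc1` differs from compound 2 by hydrogen in place of 4-methylpiperazin-1-yl on an aromatic carbon and has yet to be measured. Within the data shown here, no measured pair shows this change alone. Compound 1 also lacks that group and gives 5400 nM in the same assay, though it differs from compound 3 elsewhere too. The expected step is a 1.2-fold higher number from compound 2 to compound 3 (0.09 log units; within the scatter) in this assay and is expected to stay within the scatter, leaning slightly towards a higher number. For compound 3 the estimated value is 7000 nM with an expected range of 2500 nM to 18000 nM on this estimate.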

Compound 3, half-maximal inhibitory concentration: 34700 nM
Beside the measured number, compound 3's estimate is 5.0-fold (0.70 log units) below it, outside the stated range (above it).
By their numbers in this assay, from the lowest: compounds 1 and 2 (each within the scatter of the next); then compound 3.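

In this assay, the aromatic carbon para to a large group is not indifferent to what it carries: hydrogen in place of 4-methylpiperazin-1-yl gives a 6.1-fold higher number from compound 2 to compound 3 (0.78 log units; beyond the scatter). Hydrogen in place of phenyl on an aromatic carbon, a different place, moves the number the same way, with a 6.4-fold higher number from compound 1 to compound 3 (0.81 log units; beyond the scatter). Nothing measured here gives a reason for either step. As far as these compounds go, whether a morpholine ring or a plain amine would keep the lower number at the first place remains open. So does what phenyl and 4-methylpiperazin-1-yl would do together in one compound.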